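The compounds below may be only part of what the source reports. "The series", "measured", "known", "first", "only" and "open" are said of these compounds alone.

Compound 1 `Cc1ccc(S(=O)(=O)Nc2cc(SCC(=O)N[C@@H](CC(C)C)B(O)O)c(O)c3ccccc23)cc1` gives 8900 nM in a functional assay on A549 cells (Homo sapiens) for antiproliferative activity, read by sulforhodamine B assay, with a stated time of 72 h (on this read-out lower numbers stand for stronger inhibition and higher numbers for weaker inhibition), and is not clearly separated from its two measured relatives. Compound 2 `CC(C)C[C@H](NC(=O)CSc1cc(NS(=O)(=O)c2ccccc2)c2ccccc2c1O)B(O)O` gives 5940 nM there and compound 3 `CC(=O)Nc1ccc(S(=O)(=O)Nc2cc(SCC(=O)N[C@@H](CC(C)C)B(O)O)c(O)c3ccccc23)cc1` gives 6700 nM there, so all three numbers lie within the usual scatter of one another.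

Compound 4 `Cc1ccc(S(=O)(=O)Nc2cc(SCCC(=O)N[C@@H](CC(C)C)B(O)O)c(O)c3ccccc23)cc1` has not been measured yet. It differs from compound 1 at a single place, on a saturated chain carbon bound to a sulfur, and the change reads: a group of 12 heavy atoms (7 carbon, 1 boron, 1 nitrogen, 3 oxygen; no ring) in place of a group of 11 heavy atoms (6 carbon, 1 boron, 1 nitrogen, 3 oxygen; no ring), on a saturated chain carbon bound to a sulfur and nothing else in the structure differs.

Among the compounds with values here, no measured step touches that place. The three known steps all swap a group on an aromatic carbon. There is a 1.5-fold lower number from compound 1 to compound 2 (0.18 log units; within the scatter) with hydrogen in place of methyl, a 1.3-fold lower number from compound 1 to compound 3 (0.12 log units; within the scatter) with acetamido in place of methyl and a 1.1-fold higher number from compound 2 to compound 3 (0.05 log units; within the scatter) with acetamido in place of hydrogen. Each stays within the scatter, but together they say nothing direct about the chain.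

The starting point is therefore compound 1 at 8900 nM as the nearest guide. No change beyond the scatter is expected, and the estimated 1.1-fold lower number from compound 1 to compound 4 (0.05 log units; within the scatter) is correspondingly small. For compound 4 the expected value is 8000 nM with an estimated range from 3000 nM to 20000 nM in this estimate.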

Compound 4, half-maximal inhibitory concentration: 8190 nM
Beside the measured number, compound 4's estimate is 1.0-fold (0.01 log units) below it, within the range that was stated.
By their numbers in this assay, from the lowest: compounds 2, 3, 4 and 1 (each within the scatter of the next).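

In this assay, replacing a group of 11 heavy atoms (6 carbon, 1 boron, 1 nitrogen, 3 oxygen; no ring) with a group of 12 heavy atoms (7 carbon, 1 boron, 1 nitrogen, 3 oxygen; no ring), on a saturated chain carbon bound to a sulfur, gives a 1.1-fold lower number from compound 1 to compound 4 (0.04 log units; within the scatter) and so leaves the two compounds unseparated. Within the data shown here, this is the first reading at this position, as the earlier steps all concerned a group on an aromatic carbon, and it shows that one extra chain carbon, like those aromatic swaps, produces no difference beyond the scatter in this read-out. No supporting measurement is available to explain this result.

Going by these compounds, it remains open whether a longer chain, or an amine or a carboxylic acid on this chain, would shift the number beyond the scatter. On these data alone, it is also open whether the extra carbon would have the same outcome with the hydrogen of compound 2 or the acetamido group of compound 3 in place of the methyl of compound 4.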